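This account rests on a few compounds, and the source may have more. Where it says the series, first, only, none or still open, it means among the compounds named here.

Among the measured compounds shown here, in an assay on membranes from lung (Cavia porcellus) for binding affinity to cysteinyl leukotriene receptor (Homo sapiens) (a lower number here means a stronger inhibitor, a higher number a weaker inhibitor), compound 2 `CCCC(CCc1nnn[nH]1)Cc1cccc(OCc2ccc3ccccc3n2)c1` gives 11 nM, the lower of the two numbers measured so far. Compound 1 `O=C(O)CC1CCCC1Cc1ccc(OCc2ccc3ccccc3n2)cc1` gives 100 nM in this assay, a gap from compound 2 that lies beyond the usual scatter. Compound 3 `CCCC(CCC(=O)O)Cc1cccc(OCc2ccc3ccccc3n2)c1` differs from compound 2 by carboxy in place of 1H-tetrazol-5-yl on a saturated chain carbon, four bonds along the chain from an aromatic carbon. For the measured compounds named here, no measured pair isolates this change; compound 1 carries a carboxy group as well, but it differs from compound 2 in more than one place. Compound 3 is expected to be a weaker inhibitor than compound 2, with the step of a 3.6-fold higher number from compound 2 to compound 3 (0.56 log units; beyond the scatter) estimated as moderate and beyond the scatter. Compound 3 is estimated at 40 nM, within 10 nM to 160 nM.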

Compound 3, inhibition constant: 50 nM
For compound 3 the middle estimate is 1.3-fold (0.10 log units) below the measured one; the measured number falls inside the stated range.
By their numbers in this assay, from the lowest: compound 2; then compounds 3 and 1 (each within the scatter of the next).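

In this assay, among the compounds shown here, the pair gives the first direct reading of this change: carboxy in place of 1H-tetrazol-5-yl on a saturated chain carbon, four bonds along the chain from an aromatic carbon, brings a 4.5-fold higher number from compound 2 to compound 3 (0.66 log units; beyond the scatter). At this position, then, the 1H-tetrazol-5-yl group gives the stronger inhibitor, though the modest step shows that the carboxy compound is not far behind. Nothing available explains this difference.

The compounds shown leave open how an amide or a sulfonic acid would compare at this carbon, and whether a longer chain carrying 1H-tetrazol-5-yl would keep the lower number. From the compounds shown here alone, whether the same change would give a step of similar size on the core of compound 1 also remains open.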